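The source may hold more compounds than are shown below. What is called first, only, known or untested is meant among the compounds shown, and "the series" means these compounds.

Compound 1 `O=C1CCc2cc(OCc3cccc(Cl)c3)ccc2N1` sits at the weak end of what has been measured so far in an assay on isolated protein for inhibition of Amine oxidase [flavin-containing] A (Homo sapiens), read by fluorescence and spectrophotometry, with a stated time of 20 min; on this read-out higher numbers stand for weaker inhibition and lower numbers for stronger inhibition: compound 1 gives 50600 nM, the higher of the two numbers recorded. Compound 2 `O=C1CCc2cc(OCCCc3ccccc3)ccc2N1`, in which the phenyl group hangs from a three-carbon chain instead of a chloro-substituted benzyl ether, gives 19700 nM in this assay, and the gap between the two values lies beyond the usual scatter. Both numbers stand far out in the weak range.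

Compound 3 `O=C1CCc2cc(OCc3ccccc3)ccc2N1` is built from compound 1 by a single change, (hydrogen in place of chloro on an aromatic carbon), that is, hydrogen in place of chloro on an aromatic carbon. Among the compounds with values here, no measured pair shows this kind of change, so no direct guide to its size exists. From compound 1 the step to compound 3 is expected to be small, within or only slightly beyond the scatter, with no strong reason to favour either direction, and the estimate is a 1.1-fold lower number from compound 1 to compound 3 (0.05 log units; within the scatter). Compound 3 is thus expected to give about 45000 nM in this assay, with a plausible range from 15000 nM to 130000 nM.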

Compound 3, half-maximal inhibitory concentration: 25300 nM
Compound 3: the middle estimate sits 1.8-fold (0.25 log units) above what was measured; the range from low to high includes it.
By their numbers in this assay, from the lowest: compounds 2, 3 and 1 (each within the scatter of the next, the first and the last beyond it).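

In this assay, within the data shown here, the swap of chloro for hydrogen on the aromatic carbon meta to a large group gives a 2.0-fold lower number from compound 1 to compound 3 (0.30 log units; within the scatter) and is the first direct read on this position. Within the scatter, chloro here cannot be told apart from hydrogen, and compound 3 at 25300 nM stays in the weak range, so the activity of this pair does not depend on the chloro group. Nothing on hand offers an explanation for this step.

Still open, as far as these compounds go, is whether a different group on this aromatic carbon, such as methoxy, an amine or a carboxylic acid, would shift the number beyond the scatter. Also open, from the compounds shown here alone, is whether chloro on another carbon of this ring would behave as it does here.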